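The compounds below may be only part of what the source reports. "The series", "measured", "known", "first", "only" and "open" are said of these compounds alone.

Compound 1 `COc1cccc(S(=O)(=O)Nc2cccn(CC(=O)NCc3ccc4[nH]nc(N)c4c3)c2=O)c1`: 1930 nM
Compound 2 `Cc1cnc(NCC2(c3ccccc3)CCC2)c(=O)n1CC(=O)NCc1ccc2c(N)noc2c1`: 1310 nM
Compound 3 `Cc1ccc(NS(=O)(=O)Cc2ccccc2)c(=O)n1CC(=O)NCc1ccc2[nH]ncc2c1`: 881 nM

In an in vivo ADME assay on the whole organism (plasma) for pharmacokinetics, with Canis familiaris (Canis lupus familiaris) as the target, at a dose of 1 mg/kg by the oral route (a lower number here means less compound in the circulation, a higher number more compound in the circulation at the dose given), the three measured compounds stand close together. Compound 2 gives the second highest of the three numbers; its nearest neighbour is compound 1, and its gap to compound 3 is also within the scatter, so no order among them can be claimed. Compound 4 `Cc1cnc(NCC2(c3ccc(F)cc3)CC2)c(=O)n1CC(=O)NCc1ccc2c(N)noc2c1` has not been measured. It differs from compound 2 in one place: 1-(4-fluorophenyl)cyclopropyl in place of 1-phenylcyclobutyl on a saturated chain carbon bound to a nitrogen on an aromatic ring. For the measured compounds named here, no measured pair shows this change, so there is nothing to draw on for its size or direction; the author expects a step of a 1.0-fold lower number from compound 2 to compound 4 (0.00 log units; within the scatter), nothing beyond the scatter. Compound 4 is therefore expected to give about 1300 nM in this assay, within a range from 500 nM to 3400 nM.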

Compound 4, maximal plasma concentration: 1780 nM
Compound 4: the middle estimate sits 1.4-fold (0.14 log units) below what was measured, and the stated range covers the measured number.
By their numbers in this assay, from the lowest: compounds 3, 2, 4 and 1 (each within the scatter of the next, the first and the last beyond it).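

In this assay, 1-(4-fluorophenyl)cyclopropyl in place of 1-phenylcyclobutyl on a saturated chain carbon bound to a nitrogen on an aromatic ring gives a 1.4-fold higher number from compound 2 to compound 4 (0.13 log units; within the scatter) and so leaves the read-out indistinguishable from the scatter at this position. The change alters ring size and adds fluorine together, and this single step cannot separate the two. Nothing available accounts for the result.

On these data alone, what a 1-phenylcyclopropyl group, or an amine on the chain at this place, would give in this assay stays open.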